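This account rests on a few compounds, and the source may have more. Where it says the series, first, only, none or still open, it means among the compounds named here.

Three analogues share one core and differ only in the aryl group on the ring amine nitrogen. In an assay on brain for binding affinity to Adrenergic receptor alpha-1 (Rattus norvegicus) (on this read-out lower numbers stand for stronger inhibition and higher numbers for weaker inhibition), compound 1 `COc1cc2nc(N3CCN(c4ccncn4)CC3)nc(N)c2cc1OC` gives 0.27 nM, compound 2 `COc1cc2nc(N3CCN(c4cccnn4)CC3)nc(N)c2cc1OC` gives 0.4 nM and compound 3 `COc1ccnc(N2CCN(c3nc(N)c4cc(OC)c(OC)cc4n3)CC2)n1` gives 0.19 nM. Among the three, compound 2 has the highest number; the gap to compound 1, a 1.5-fold higher number from compound 1 to compound 2 (0.17 log units; within the scatter), lies within the scatter, while a 2.1-fold lower number from compound 2 to compound 3 (0.32 log units; beyond the scatter) lies beyond it. Compound 4 `COc1cc2nc(N3CCN(c4nccc(N(C)C)n4)CC3)nc(N)c2cc1OC` has not been measured; it differs from compound 2 by 4-(dimethylamino)pyrimidin-2-yl in place of pyridazin-3-yl on an amine nitrogen in a ring. For the measured compounds named here, the closest precedent is a 2.1-fold lower number from compound 2 to compound 3 (0.32 log units; beyond the scatter), which also replaced pyridazin-3-yl with a substituted pyrimidin-2-yl, and a 1.4-fold lower number from compound 1 to compound 3 (0.15 log units; within the scatter) stayed within the scatter. A modest lowering of similar size is therefore expected, estimated as a 1.6-fold lower number from compound 2 to compound 4 (0.20 log units; within the scatter). Compound 4 is expected near 0.25 nM, with a range from 0.12 nM to 0.5 nM.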

Compound 4, inhibition constant: 0.27 nM
Beside the measured number, compound 4's estimate is 1.1-fold (0.03 log units) below it, within the range that was stated.
By their numbers in this assay, from the lowest: compounds 3, 1, 4 and 2 (each within the scatter of the next, the first and the last beyond it).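

Placing 4-(dimethylamino)pyrimidin-2-yl on the amine nitrogen in a ring keeps the number within the scatter of all three earlier compounds in this assay: a 1.5-fold lower number from compound 2 to compound 4 (0.17 log units; within the scatter), a 1.4-fold higher number from compound 3 to compound 4 (0.15 log units; within the scatter), and no change at the digits printed from compound 1 to compound 4 (within the scatter). The pyrimidin-2-yl group thus accepts dimethylamino in place of methoxy on an aromatic carbon without a step beyond the scatter. No available evidence bears on this result. On these data alone, it remains open whether phenyl on this nitrogen, or a carboxylic acid in place of dimethylamino, would keep the number in this range.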